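Shifting the halogen on a benzyl sulfide side chain

The source may report more compounds than this note shows. Statements on the series, on what has been measured and on what is new or still open speak of the compounds shown alone.

Compound 1 `CC1=C(C(=O)Nc2ccc(Br)cc2)C(c2ccc(Cl)cc2Cl)N=C(SCc2ccccc2Cl)N1` and compound 2 `CC1=C(C(=O)Nc2ccc(Br)cc2)C(c2ccc(Cl)cc2Cl)N=C(SCc2cccc(Cl)c2)N1` share one core and differ only in the ring attached to a saturated chain carbon bound to a sulfur. In a functional assay on the whole organism (artery, strain albino) with Rattus norvegicus as the target, with a stated time of 180 min, at a dose of 10 mg/kg by the oral route (on this read-out higher numbers stand for more inhibition at the one dose given (going by the name of the read-out) and lower numbers for less inhibition), compound 1 gives 22.2%, while compound 2 gives 11.9%. For the measured compounds named here, compound 2 thus holds the lower of the two numbers, and the only known step, a number 10.3 percentage points lower from compound 1 to compound 2 (beyond the scatter), separates it from compound 1.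

Compound 3 `CC1=C(C(=O)Nc2ccc(Br)cc2)C(c2ccc(Cl)cc2Cl)N=C(SCc2ccc(F)cc2)N1` is the next member: 4-fluorophenyl in place of 3-chlorophenyl on a saturated chain carbon bound to a sulfur. Going by the values given here, only the step from compound 1 to compound 2 bears on this change, and it was modest. Since the new change again alters only the halogen and its position on that ring, the expected step of a number 3.1 percentage points higher from compound 2 to compound 3 (within the scatter) is small, with no clear direction. Compound 3 is estimated at 15%, within a range from 0% to 32%.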

Compound 3, a percentage reported as inhibition, in the whole organism at one dose (the size of the read-out at that dose, not a potency): 28.4%
Beside the measured number, compound 3's estimate is 13.4 percentage points below it; low and high end bracket the measured number.
By their numbers in this assay, from the lowest: compound 2; then compounds 1 and 3 (each within the scatter of the next).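

On this saturated chain carbon bound to a sulfur, the ring can move the number in both directions: in this assay, 4-fluorophenyl in place of 3-chlorophenyl gives a number 16.5 percentage points higher from compound 2 to compound 3 (beyond the scatter) and so reverses the earlier fall. Replacing 2-chlorophenyl with 4-fluorophenyl gives a number 6.2 percentage points higher from compound 1 to compound 3 (within the scatter), so these two rings cannot be told apart here, and compound 2 alone stands lowest of the three. Nothing available explains why the 3-chlorophenyl ring stands apart.

For the compounds shown here, with only three rings, each differing in both halogen and position, the effect of the halogen cannot be separated from that of its position. On these data alone, it also remains open how 4-chlorophenyl, an unsubstituted phenyl ring or a longer chain carrying the ring would behave at this place.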